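A few compounds are considered here, and "the series" means these few. Any claim that something is new, unique, unknown or untested is made for them only; others in the source may bear on it.

Within the data shown here, compound 2 `O=C(CCc1nnc(-c2ccc([N+](=O)[O-])cc2)o1)c1ccccc1` stands highest of the two numbers so far: in a functional assay on the whole organism (strain Wistar) for inhibition, with Rattus norvegicus as the target, with stated times of 30 min and 2 h, at a dose of 20 mg/kg by the oral route (on this read-out higher numbers stand for more inhibition at the one dose given (going by the name of the read-out) and lower numbers for less inhibition), compound 2 gives 40.9%, while compound 1 `O=C(CCc1nnc(-c2ccccc2)o1)c1ccccc1` gives 18.7%. Among the measured compounds shown here, the one measured step, a number 22.2 percentage points higher from compound 1 to compound 2 (beyond the scatter), concerns the ring attached to the five-membered aromatic ring of the shared core. Compound 3 `Cc1ccc(C(=O)CCc2nnc(-c3ccc([N+](=O)[O-])cc3)o2)c(C)c1` differs from compound 2 by 2,4-dimethylphenyl in place of phenyl on a carbonyl carbon. For the measured compounds named here, no measured step touches the ring on the carbonyl carbon, so the step of a number 0.1 percentage points higher from compound 2 to compound 3 (within the scatter) is expected to remain within the scatter. Compound 3 is therefore estimated at 41% in this assay, with a range from 25% to 57%.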

Compound 3, a percentage reported as inhibition, in the whole organism at one dose (the size of the read-out at that dose, not a potency): 40%
Compound 3: middle estimate off by 1 percentage points, on the high side, and the stated range covers the measured number.
By their numbers in this assay, from the lowest: compound 1; then compounds 3 and 2 (each within the scatter of the next).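

In this assay, 2,4-dimethylphenyl in place of phenyl on a carbonyl carbon gives a number 0.9 percentage points lower from compound 2 to compound 3 (within the scatter), so the larger group leaves the read-out unchanged within the scatter. Among these compounds, this is the first reading at this position, as the earlier step concerned only nitro in place of hydrogen on an aromatic carbon. Nothing at hand gives a reason for this result. Open, from the compounds shown here alone, is whether an amine or a carboxylic acid on this ring would shift the read-out. Also open, going by these compounds, is whether the same change holds on compound 1, which has no nitro.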